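Swapping a fluorobenzyl ether for a dichlorobenzyl ether

The source may hold more compounds than are shown below. What is called first, only, known or untested is meant among the compounds shown, and "the series" means these compounds.

Measured so far:
compound 1 `Cc1ccc(NC(=S)NC(=O)c2ccc(OCc3ccccc3)cc2)cc1-c1nc2ccccc2[nH]1`, 28800 nM
compound 2 `Cc1ccc(NC(=S)NC(=O)c2ccc(OCc3ccccc3F)cc2)cc1-c1nc2ccccc2[nH]1`, 1870 nM
compound 3 `Cc1ccc(NC(=S)NC(=O)c2ccc(OCc3ccccc3Cl)cc2)cc1-c1nc2ccccc2[nH]1`, 23700 nM

All three compounds share one core and differ only in the group on the benzyl ether. In a functional assay on HT-29 cells (Homo sapiens) for inhibition, read by MTT assay, with a stated time of 48 h (on this read-out lower numbers stand for stronger inhibition and higher numbers for weaker inhibition), compound 2 gives the lowest number of the three: compound 3 is a 13-fold higher number from compound 2 to compound 3 (1.10 log units; beyond the scatter), and compound 1 sits furthest away, a 15-fold lower number from compound 1 to compound 2 (1.19 log units; beyond the scatter) in the other direction. Compound 1 and compound 3 lie within the scatter of each other, so no order between them can be claimed.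

Compound 4 `Cc1ccc(NC(=S)NC(=O)c2ccc(OCc3ccc(Cl)c(Cl)c3)cc2)cc1-c1nc2ccccc2[nH]1` has not yet been measured. It differs from compound 2 by 3,4-dichlorophenyl in place of 2-fluorophenyl on a saturated chain carbon bound to an oxygen on an aromatic ring. For the measured compounds named here, two measured steps bear on this. The step from compound 1 to compound 2 shows that fluoro alone drove the whole drop, and the step of a 13-fold higher number from compound 2 to compound 3 (1.10 log units; beyond the scatter) shows that chloro in the position of that fluoro gave most of it back. Going by the values given here, compound 4 keeps no fluoro and carries chloro at places no measured compound covers, so nothing shows chloro helping here. The expectation is therefore a large step upward in this assay, an 8.0-fold higher number from compound 2 to compound 4 (0.90 log units; beyond the scatter), towards the numbers of compound 1 and compound 3. Compound 4 is estimated at 15000 nM, with a range from 3000 nM to 60000 nM.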

Compound 4, half-maximal inhibitory concentration: 6270 nM
For compound 4 the middle estimate is 2.4-fold (0.38 log units) above the measured one, and the stated range covers the measured number.
By their numbers in this assay, from the lowest: compound 2; then compound 4; then compounds 3 and 1 (each within the scatter of the next).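

In this assay, for the compounds shown here, the 3,4-dichlorophenyl group shows that a benzyl ether without fluoro can still lower the number, something the single chloro of compound 3 did not do: the change gives a 3.8-fold lower number from compound 3 to compound 4 (0.58 log units; beyond the scatter), and against the unsubstituted phenyl it gives a 4.6-fold lower number from compound 1 to compound 4 (0.66 log units; beyond the scatter). So at this position, the effect of chloro depends on how the ring is substituted, and fluoro is no longer the only change seen to lower the number, although 2-fluorophenyl still gives the lowest value of the four, with a 3.4-fold higher number from compound 2 to compound 4 (0.53 log units; beyond the scatter). No measurement here explains why these rings differ in this way.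

As far as these compounds go, compound 4 carries two chloro groups, neither at the place of the chloro in compound 3, so the share of each one in the step remains open, and a ring with just one of them would be needed to separate the two. From the compounds shown here alone, how a methoxy group, an amine or a carboxylic acid on this ring would compare with the halogens also remains open.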